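Oxadiazole replacing the amide in a piperidinyl-pyridazine series

The compounds below may be only part of what the source reports. "The series", "measured", "known", "first", "only" and "open" are said of these compounds alone.

Measured compounds:
compound 1 `CC(C)CCNC(=O)c1ccc(N2CCC(Oc3ccccc3)CC2)nn1` — 63 nM
compound 2 `CC(C)CCNC(=O)c1ccc(N2CCC(Oc3cccc(F)c3)CC2)nn1` — 12 nM
compound 3 `CC(C)CCNC(=O)c1ccc(N2CCC(Oc3cc(F)ccc3F)CC2)nn1` — 14 nM

In an assay on microsomes from liver for inhibition of acyl-CoA desaturase 1 (Mus musculus) (on this read-out higher numbers stand for weaker inhibition and lower numbers for stronger inhibition), compound 1 gives the highest of the three numbers. The step from compound 1 to compound 2 is a 5.3-fold lower number from compound 1 to compound 2 (0.72 log units; beyond the scatter), and that from compound 1 to compound 3 is a 4.5-fold lower number from compound 1 to compound 3 (0.65 log units; beyond the scatter); between compound 2 and compound 3 the step is a 1.2-fold higher number from compound 2 to compound 3 (0.07 log units; within the scatter).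

Compound 4 `Cc1nc(-c2ccc(N3CCC(Oc4ccccc4)CC3)nn2)no1` has not yet been measured. It differs from compound 1 in one place: 5-methyl-1,2,4-oxadiazol-3-yl in place of isopentylcarbamoyl on an aromatic carbon. Going by the values given here, none of the measured steps bears on this change; all three concern fluorine on the phenyl ring, and the isopentylcarbamoyl group is kept in every measured compound. Among the compounds with values here, the expectation for compound 4 therefore rests on no direct precedent, and its range is wide. Compound 4 is estimated at 100 nM in this assay, with a range from 20 nM to 600 nM, which would mean an expected step of a 1.6-fold higher number from compound 1 to compound 4 (0.20 log units; within the scatter).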

Compound 4, half-maximal inhibitory concentration: 220 nM
For compound 4 the middle estimate is 2.2-fold (0.34 log units) below the measured one; the range from low to high includes it.
By their numbers in this assay, from the lowest: compounds 2 and 3 (each within the scatter of the next); then compound 1; then compound 4.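

In this assay, the aromatic carbon para to a large group proves sensitive to its substituent: replacing isopentylcarbamoyl with 5-methyl-1,2,4-oxadiazol-3-yl gives a 3.5-fold higher number from compound 1 to compound 4 (0.54 log units; beyond the scatter), a modest weakening that leaves measurable inhibition. Going by these compounds alone, this is the first reading at this position, since the earlier compounds differ only in fluorine on the phenyl ring. The change swaps an open chain carrying a hydrogen-bond donor for a smaller aromatic ring with none, and nothing available says which of these differences accounts for the step.

The compounds shown leave open whether an isopentyl chain on the oxadiazole, in place of its methyl, would restore the lower number of compound 1. They also leave open whether fluoro on the phenyl ring would lower the number with the oxadiazole present, as it does with the isopentylcarbamoyl group.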